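The source may report more compounds than this note shows. Statements on the series, on what has been measured and on what is new or still open speak of the compounds shown alone.

Working notes on the series. Compound 1 `O=C1C=C(N2CCC2)C(=O)c2c1nc1n2[C@H]2OC[C@@H](O)[C@H]2OC1` and compound 2 `Cc1ccc(NC2=CC(=O)c3c(nc4n3[C@H]3OC[C@@H](O)[C@H]3OC4)C2=O)cc1C` share one core and have both been read in a functional assay on ECa-109 cells for inhibition, with ECa-109 cell line (Homo sapiens) as the target, read by sulforhodamine B assay; on this read-out higher numbers stand for weaker inhibition and lower numbers for stronger inhibition. In this assay compound 2 gives 4090 nM. For compound 1 the read-out reached only a limit of the assay, > 16000 nM, so no number of its own exists for it. Among the compounds with values here, of the two values shown, compound 1 sits at the limit of > 16000 nM in this assay, at which 1 of the 2 values shown sits, the weak end of what has been recorded, and compound 2 holds the only numeric value in the set.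

Compound 3 `O=C1C=C(N2CCCCC2)C(=O)c2c1nc1n2[C@H]2OC[C@@H](O)[C@H]2OC1` is not yet measured in this assay. It differs from compound 1 in one place: piperidin-1-yl in place of azetidin-1-yl on a double-bonded ring carbon. Within the data shown here, no step between two measured compounds covers this exchange, and since compound 1 carries only a limit, any step from it can be bounded but not counted. Compound 3 is expected to give about 12000 nM, with a range from 4000 nM to 40000 nM. The expected step of an at least 1.3-fold lower number from compound 1 to compound 3 (0.12 log units; that floor lies within the scatter) is small, toward stronger inhibition if anything, and a second limit is a real possibility.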

Compound 3, half-maximal inhibitory concentration: > 8000 nM
Compound 3 ended at the assay's limit; the forecaster's own chance of this, stated with the estimate: 50%; the middle value is on the limit's open side.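

In this assay compound 3 gives > 8000 nM, a limit of the assay. Compound 1 also carries only a limit, and the step between compound 1 and compound 3 cannot be read. The compounds shown leave open whether piperidin-1-yl in place of azetidin-1-yl changes inhibition at all, in either direction.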